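A few compounds are considered here, and "the series" means these few. Any claim that something is new, unique, unknown or untested is made for them only; others in the source may bear on it.

Of the compounds shown here, two built on a shared core have been read in an ADME assay on HFF cells (Homo sapiens) for cytotoxicity, with a stated time of 8 days; on this read-out higher numbers stand for lower toxicity in this test and lower numbers for higher toxicity in this test. Compound 1 `CC(C)CNc1nc(N)nc2c1ncn2/C=C1/CC1(CO)CO`, carrying isobutylamino, gives > 300000 nM, which is a limit of the assay and not a number. Going by the values given here, compound 2 `CCCCCOc1nc(N)nc2c1ncn2/C=C1/CC1(CO)CO`, carrying pentyloxy at that carbon, gives 259000 nM, the only true number so far in this assay.

The next compound, compound 3 `Nc1nc(SC2CCCC2)c2ncn(/C=C3/CC3(CO)CO)c2n1`, changes that same group again: cyclopentylsulfanyl in place of pentyloxy on an aromatic carbon. Cyclopentylsulfanyl stands in place of pentyloxy on an aromatic carbon.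

Among the compounds with values here, only one measured step bears on this change, the exchange of isobutylamino for pentyloxy, an at least 1.1-fold lower number from compound 1 to compound 2 (0.06 log units; that floor lies within the scatter). From the compounds shown here alone, its floor lies within the scatter, and its true size remains open. An exchange at this carbon has therefore not been shown to move the read-out in this assay beyond the scatter, although no measured step yet involves a cyclopentylsulfanyl group. On the strength of an at least 1.1-fold lower number from compound 1 to compound 2 (0.06 log units; that floor lies within the scatter), the expected change is small and slightly downward, a 1.3-fold lower number from compound 2 to compound 3 (0.11 log units; within the scatter), with no step beyond the scatter anticipated. The estimate for compound 3 is 200000 nM, with an expected range from 70000 nM to 300000 nM.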

Compound 3, half-maximal cytotoxic concentration: > 300000 nM
Compound 3: a limit, no number; the forecaster's own chance of this, stated with the estimate: 30%; middle value at least 1.5-fold (0.17 log units) away from the limit.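

In this assay, the exchange of pentyloxy for cyclopentylsulfanyl gives an at least 1.1-fold higher number from compound 2 to compound 3 (0.06 log units; that floor lies within the scatter), so a group with a five-membered non-aromatic ring of carbon only, attached through sulfur, does not bring the read-out clearly lower than the open pentyloxy chain does. Compound 3 gives > 300000 nM, a limit of the assay and not a number, and this carbon has now carried isobutylamino, pentyloxy and cyclopentylsulfanyl with no step shown beyond the scatter. The step between compound 1 and compound 3 cannot be read, and this read-out can separate the groups at this carbon only poorly, because the readings stop at a single limit: the limit of > 300000 nM in this assay, at which 2 of the 3 values shown sit.

From the compounds shown here alone, the true sizes of the steps remain open, as does how far compound 1 and compound 3 lie past that limit. Also open, going by these compounds, is whether a carboxylic acid, a phenylsulfanyl group or a longer alkoxy chain at this carbon would move the read-out in this assay beyond the scatter, and whether a change elsewhere on the shared core would do so.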